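Phenyl in place of isopropyl: what to expect

This account rests on a few compounds, and the source may have more. Where it says the series, first, only, none or still open, it means among the compounds named here.

Measured in an ADME assay on AGS cells (Homo sapiens) for cytotoxicity, read by neutral red uptake, with a stated time of 24 h; on this read-out lower numbers stand for stronger inhibition and higher numbers for weaker inhibition:
Compound 1 `CC(C)C(=O)Oc1c(C(C)C)cc2c3c1OC(=O)[C@@]31CCCC(C)(C)[C@@H]1CC2`: 105000 nM
Compound 2 `CCCCCCCCCCCCCCCC(=O)Oc1c(C(C)C)cc2c3c1OC(=O)[C@@]31CCCC(C)(C)[C@@H]1CC2`: > 1000000 nM (a limit of the assay)
Compound 3 `CCCCC/C=C/C/C=C/CCCCCCCC(=O)Oc1c(C(C)C)cc2c3c1OC(=O)[C@@]31CCCC(C)(C)[C@@H]1CC2`: 253000 nM

Compound 1 holds the lower of the two true numbers in this assay. It reads 105000 nM, while its nearest neighbour, compound 3, reads 253000 nM. Compound 2 gives > 1000000 nM, which is a limit and not a number.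

The next compound, compound 4 `CC(C)c1cc2c3c(c1OC(=O)c1ccccc1)OC(=O)[C@@]31CCCC(C)(C)[C@@H]1CC2`, has not yet been measured. It differs from compound 1 by phenyl in place of isopropyl on a carbonyl carbon, so isopropylcarbonyl gives way to benzoyl.

Going by the values given here, no measured step makes this change. Among the compounds with values here, the only step on record is an at least 3.9-fold lower number from compound 2 to compound 3 (0.59 log units; beyond the scatter), and it concerns long chains, so it bears on the present change only loosely. A weak hint of direction comes from compound 3 at 253000 nM, whose long acyl chain reads higher than the short acyl group of compound 1. A small step towards a higher number is therefore expected, and it may well stay within the scatter. The expected change is a 1.3-fold higher number from compound 1 to compound 4 (0.12 log units; within the scatter).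

For compound 4 the estimated value is 140000 nM, with an expected range from 55000 nM to 380000 nM.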

Compound 4, half-maximal inhibitory concentration: 503000 nM
Estimate against measurement, compound 4: 3.6-fold (0.56 log units) below, and the stated range ends below it.
By their numbers in this assay, from the lowest: compound 1; then compounds 3 and 4 (each within the scatter of the next). At a limit, above all of these: compound 2.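

In this assay, going by these compounds alone, the carbonyl carbon carries a ring for the first time, and replacing isopropylcarbonyl with benzoyl gives a 4.8-fold higher number from compound 1 to compound 4 (0.68 log units; beyond the scatter). This shows that a change confined to a short acyl group, with no long chain involved, can move the read-out beyond the scatter, and that the isopropyl of compound 1 goes with a lower number here than the phenyl of compound 4. Compound 4 also lies within the scatter of compound 3, so a phenyl on this carbonyl carbon and a long unsaturated chain cannot be told apart in this read-out.

On these data alone, it remains open whether the higher number follows the aromatic ring as such, which a cyclohexyl group on the same carbonyl carbon could test, and whether an amine or a carboxylic acid on the phenyl would shift the number in either direction. How compound 2 ranks also stays open, as its value is a limit and not a number: the limit of > 1000000 nM in this assay, at which 1 of the 4 values shown sits.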